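Series notes: replacing the acid-bearing bicycle in compound 1

The source may hold more compounds than are shown below. What is called first, only, known or untested is meant among the compounds shown, and "the series" means these compounds.

Measured so far:
compound 1 `O=C(O)c1ccc2nc(CN3CCC[C@H](O[C@H](CO)c4cc(Cl)cc(Cl)c4)[C@@H]3c3ccccc3)[nH]c2c1` — 380 nM
compound 2 `Cc1cc(C(=O)O)ccc1CN1C(C)CC[C@H](O[C@H](CO)c2cc(Cl)cc(Cl)c2)[C@@H]1c1ccccc1` — 36000 nM
compound 3 `Cc1cc(C(=O)O)ccc1CN1CCC[C@H](O[C@H](CO)c2ccnc(Cl)c2)[C@@H]1c1ccccc1` — 50000 nM

In an assay on isolated protein for activation of cGMP-dependent protein kinase 1 (Homo sapiens), read by ADP-Glo, with stated times of 30 min and 2 h, in the presence of a further agent that is not named here (a higher number here means that more compound is needed for the effect, a lower number that less compound is needed), compound 1 gives 380 nM, the lowest of the three numbers. Compound 2 gives 36000 nM and compound 3 gives 50000 nM; both gaps to compound 1 are well beyond the scatter, though each of those two compounds differs from compound 1 in more than one place, so neither gap can be tied to a single change.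

Compound 4 `Nc1cc(C(=O)O)ccc1CN1CCC[C@H](O[C@H](CO)c2cc(Cl)cc(Cl)c2)[C@@H]1c1ccccc1` is not yet measured in this assay. Relative to compound 1 the change is a group of 10 heavy atoms (7 carbon, 1 nitrogen, 2 oxygen; one six-membered aromatic ring of carbon only) in place of a group of 12 heavy atoms (8 carbon, 2 nitrogen, 2 oxygen; one five-membered aromatic ring with 2 hetero atoms, one six-membered aromatic ring of carbon only), on a saturated chain carbon bound to an amine nitrogen in a ring. The rest of the shared core, including the dichlorophenyl side chain and the unsubstituted saturated ring, is kept.

Among the compounds with values here, no single-change step is available to anchor this. The two weaker compounds both carry a carboxyphenyl in place of the bicycle, together with other changes, and both sit far above compound 1. Since compounds 2 and 3 carry those further changes, their gaps to compound 1 likely overstate what this single change alone would do. A sizeable loss is therefore expected for a 7.9-fold higher number from compound 1 to compound 4 (0.90 log units; beyond the scatter), smaller than the gaps to compounds 2 and 3. Compound 4 is expected to give about 3000 nM, within 700 nM to 15000 nM.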

Compound 4, half-maximal effective concentration: 290 nM
Estimate against measurement, compound 4: 10-fold (1.01 log units) above, and the stated range ends above it.
By their numbers in this assay, from the lowest: compounds 4 and 1 (each within the scatter of the next); then compounds 2 and 3 (each within the scatter of the next).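

In this assay, within the data shown here, the single change reads as a 1.3-fold lower number from compound 1 to compound 4 (0.12 log units; within the scatter) and so stands within the usual scatter. On the saturated chain carbon bound to an amine nitrogen in a ring, the 12-heavy-atom group with its five-membered aromatic ring can therefore give way to 2-amino-4-carboxyphenyl, with its one six-membered aromatic ring of carbon only, and no difference can be read between the two groups in this assay, with the rest of the shared core kept. Compound 2 and compound 3 each differ from compound 4 in more than one place, so their values cannot be read against it as steps, and nothing available bears on why the two groups read alike.

The compounds shown leave open what the amino group of the 2-amino-4-carboxyphenyl contributes, which a hydrogen or a hydroxyl in its place on compound 4 would address. They also leave open whether the carboxylic acid must stay on this ring, which a tetrazole in its place would address.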